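This account rests on a few compounds, and the source may have more. Where it says the series, first, only, none or still open, it means among the compounds named here.

Three related compounds have so far been tested in a functional assay on the whole organism with Homo sapiens as the target; on this read-out lower numbers stand for an effect already at smaller amounts and higher numbers for an effect only at larger amounts of compound. Compound 1 `CC(O)(C(=O)Nc1cccc(C(=O)c2ccccc2)c1)C(F)(F)F` gives 10000 nM, and compound 2 `CC(O)(C(=O)Nc1ccc(C(=O)c2ccccc2)cc1Cl)C(F)(F)F` gives 30000 nM. Compound 3 `C[C@@](O)(C(=O)Nc1ccc(C(=O)O)cc1Cl)C(F)(F)F` gives 1400 nM. Compound 2 therefore has the highest number of the three, meaning that it takes the largest amount of compound to produce the effect, and its gaps to both of the others lie beyond the scatter.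

Compound 4 `CC(O)(C(=O)Nc1ccc(C(=O)N2CCCCC2)cc1Cl)C(F)(F)F` has not yet been measured. It differs from compound 2 in one place: piperidin-1-yl in place of phenyl on a carbonyl carbon. In words, piperidin-1-yl stands in place of phenyl on a carbonyl carbon, so benzoyl becomes (piperidin-1-yl)carbonyl.

Going by the values given here, no measured pair shows what this exchange does on its own, so any forecast is uncertain. The only hint is indirect. Compound 1 and compound 2 both carry benzoyl, while compound 3 does not, and compound 3 at 1400 nM has a lower number than compound 2 at 30000 nM. However, these two compounds differ in more than the benzoyl group.

A moderate move toward a lower number, beyond the scatter, is therefore expected, with a 4.3-fold lower number from compound 2 to compound 4 (0.63 log units; beyond the scatter) as the estimated step. The estimated value for compound 4 is 7000 nM, with an expected range from 1500 nM to 30000 nM.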

Compound 4, half-maximal effective concentration: 710 nM
Beside the measured number, compound 4's estimate is 9.9-fold (0.99 log units) above it, outside the stated range (below it).
By their numbers in this assay, from the lowest: compounds 4 and 3 (each within the scatter of the next); then compound 1; then compound 2.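

Read on its own for the first time, the exchange of phenyl for piperidin-1-yl on a carbonyl carbon gives, in this assay, a 42-fold lower number from compound 2 to compound 4 (1.63 log units; beyond the scatter), so this position responds strongly to what is attached there. The size of the step is notable for such a small exchange: both groups are six-membered rings with the same number of heavy atoms, and neither is counted as having a hydrogen-bond donor or acceptor, yet an aromatic ring of carbon only gives way to a non-aromatic ring holding a nitrogen. No measurement of any property is available to explain the size of this step.

The compounds shown leave open whether the nitrogen or the loss of the aromatic ring matters more: cyclohexyl on the same carbonyl carbon would keep a non-aromatic ring without the nitrogen, while diethylamino would keep the nitrogen without a ring. From the compounds shown here alone, this exchange also rests on a single pair, so whether it gives a similar step on a different core remains open.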